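The compounds below may be only part of what the source reports. "The series", "measured", "known", "first", "only" and "open" are said of these compounds alone.

Measured so far in an ADME assay on HepG2 cells (Homo sapiens) for cytotoxicity, read by MTT assay, with a stated time of 7 days; on this read-out lower numbers stand for stronger inhibition and higher numbers for weaker inhibition:
- compound 1 `CC(C)Oc1ccc(C2CC(c3ccc(O)cc3)=NN2C(=O)c2cccnc2)cc1`: 45400 nM
- compound 2 `CCCc1ccc(C2CC(c3ccc(O)cc3)=NN2C(=O)c2cccnc2)cc1`: 41600 nM
- compound 3 `O=C(c1cccnc1)N1N=C(c2ccc(O)cc2)CC1c1ccc([N+](=O)[O-])cc1`: 18600 nM

Compound 2 shares the upper end of these three numbers with compound 1, and the pair shows a 1.1-fold lower number from compound 1 to compound 2 (0.04 log units; within the scatter). The lowest number belongs to compound 3, with a 2.2-fold lower number from compound 2 to compound 3 (0.35 log units; beyond the scatter).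

Compound 4 `O=C(c1cccnc1)N1N=C(c2ccc(O)cc2)CC1c1ccc(F)cc1` carries fluoro in place of propyl on an aromatic carbon. Within the data shown here, no measured compound carries fluoro, so the evidence is indirect. The same place gave a 2.4-fold lower number from compound 1 to compound 3 (0.39 log units; beyond the scatter) and, from propyl, the nitro step above. Both are modest, so a small step toward a lower number in this assay is expected, possibly not beyond the scatter. The expected step is a 1.4-fold lower number from compound 2 to compound 4 (0.14 log units; within the scatter). Compound 4 is estimated at 30000 nM, with an expected range of 15000 nM to 55000 nM.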

Compound 4, half-maximal inhibitory concentration: 52400 nM
Compound 4: the middle estimate sits 1.7-fold (0.24 log units) below what was measured, and the stated range covers the measured number.
By their numbers in this assay, from the lowest: compound 3; then compounds 2, 1 and 4 (each within the scatter of the next).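

Exchanging propyl for the single fluorine leaves this assay within the scatter (a 1.3-fold higher number from compound 2 to compound 4 (0.10 log units; within the scatter)), and fluoro also stays level with isopropoxy (a 1.2-fold higher number from compound 1 to compound 4 (0.06 log units; within the scatter)). At this position, a small group therefore does not follow nitro toward the lower number, and nitro alone stands apart (a 2.8-fold higher number from compound 3 to compound 4 (0.45 log units; beyond the scatter)). No supporting data bear on why nitro differs.

Still open, going by these compounds, is whether an amine, a carboxylic acid or a nitrile here would join nitro or the other three groups. A longer chain would test whether the level extends beyond propyl.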